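This account rests on a few compounds, and the source may have more. Where it says the series, first, only, none or still open, it means among the compounds named here.

Of the compounds shown here, three sharing one core have been measured in a functional assay (muscle tissue) with Cavia porcellus as the target; a higher number here means that more compound is needed for the effect, a lower number that less compound is needed. Compound 1 `COC(=O)C1=C(C)N=C(C)/C(=C(\O)OC)C1c1ccc(Cl)cc1` gives 8130 nM, compound 2 `C=Cc1ccccc1C1C(C(=O)OC)=C(C)N=C(C)/C1=C(\O)OC` gives 4.47 nM, and compound 3 `COC(=O)C1=C(C)N=C(C)/C(=C(\O)OC)C1c1cc(Cl)cc(Cl)c1` gives 93.3 nM. Compound 3 therefore stands second of the three: the step of a 21-fold higher number from compound 2 to compound 3 (1.32 log units; beyond the scatter) places it clearly after compound 2, while the step of an 87-fold lower number from compound 1 to compound 3 (1.94 log units; beyond the scatter) places it clearly ahead of compound 1.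

Compound 4 `COC(=O)C1=C(C)N=C(C)/C(=C(\O)OC)C1c1ccccc1C` differs from compound 3 in one place: 2-methylphenyl in place of 3,5-dichlorophenyl on a saturated ring carbon.

Among the compounds with values here, two measured steps bear on this change. The step of a 21-fold higher number from compound 2 to compound 3 (1.32 log units; beyond the scatter) shows that a 3,5-dichlorophenyl on that saturated ring carbon needs more compound than a 2-vinylphenyl, and the step of a 1800-fold lower number from compound 1 to compound 2 (3.26 log units; beyond the scatter) shows that the 2-vinylphenyl needs far less than a 4-chlorophenyl. The 2-methylphenyl of compound 4 resembles the 2-vinylphenyl of compound 2 more closely than either chlorine-bearing group, so a lower number than compound 3 is expected in this assay, with the step from compound 3 to compound 4 estimated at a 7.8-fold lower number from compound 3 to compound 4 (0.89 log units; beyond the scatter). Within the data shown here, on this basis compound 4 is expected to give about 12 nM in this assay, within a range of 2 nM to 60 nM, since only one compound with a substituent of this kind has been measured.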

Compound 4, half-maximal effective concentration: 6.03 nM
Estimate against measurement, compound 4: 2.0-fold (0.30 log units) above, within the range that was stated.
By their numbers in this assay, from the lowest: compounds 2 and 4 (each within the scatter of the next); then compound 3; then compound 1.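

In this assay, 2-methylphenyl needs far less compound than 3,5-dichlorophenyl (a 15-fold lower number from compound 3 to compound 4 (1.19 log units; beyond the scatter)) and far less than 4-chlorophenyl (a 1300-fold lower number from compound 1 to compound 4 (3.13 log units; beyond the scatter)). The step between the two low compounds (a 1.3-fold higher number from compound 2 to compound 4 (0.13 log units; within the scatter)) means that 2-methylphenyl and 2-vinylphenyl cannot be told apart here, so on this saturated ring carbon the low number of compound 2 does not require a vinyl group: in compound 4, a plain methyl in its place does just as well. Nothing measured here explains why these two groups stand so far from the chlorine-bearing groups of compound 1 and compound 3.

The compounds shown leave open whether the low number requires a carbon group on the phenyl at all, or whether a 2-chlorophenyl, with a single chlorine in the place the methyl holds, would give a similarly low number. Also open, as far as these compounds go, is whether a longer chain, as in a 2-propylphenyl, or an amine, as in a 2-aminophenyl, would keep the number as low.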